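Inverting two stereocentres of compound 1

The source may report more compounds than this note shows. Statements on the series, on what has been measured and on what is new or still open speak of the compounds shown alone.

Compound 1 `O=C(c1ccc(O)cc1O)[C@@H]1[C@H](C(=O)c2ccc(O)cc2O)[C@@H](c2ccccc2)[C@H]1c1ccccc1` was examined in a functional assay on PC-3 cells (Homo sapiens) for cytotoxicity, read by MTT assay, with a stated time of 48 h, tested at 5 uM (a lower number here means a weaker effect, a higher number a stronger effect of the compound at the concentration tested), where compound 1 gives 27.1%. On the numbers shown, compound 1 stands at the top of two, but its only companion sits within the scatter: in this assay compound 2 `O=C(c1ccc(O)cc1O)[C@@H]1Cc2ccccc2[C@H](C(=O)c2ccc(O)cc2O)[C@@H]1c1ccccc1` gives 22.3%, so nothing separates the two. Going by the values given here, no change that touches one place at a time links compound 1 and compound 2, and no measured step exists.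

Compound 3 `O=C(c1ccc(O)cc1O)[C@H]1[C@H](C(=O)c2ccc(O)cc2O)[C@@H](c2ccccc2)[C@@H]1c1ccccc1` has not yet been tested. Compared with compound 1, (the two compounds have the same atoms and bonds and differ only in configuration as drawn: 2 of 4 stereo elements differ; a stereocentre at a saturated ring carbon is drawn S in compound 1 and R in compound 3; a stereocentre at a saturated ring carbon is drawn R in compound 1 and S in compound 3). Nothing leaves and nothing enters; only two of the four stereo elements are drawn the other way round.

Among the compounds with values here, with no measured step to lean on, and with both values so far close together, the expected step is a number 2.1 percentage points lower from compound 1 to compound 3 (within the scatter), within the scatter and in no settled direction. Within the data shown here, compound 3 is expected to give about 25% in this assay, with a plausible range from 10% to 42%, the width reflecting that the data hold no stereoisomer pair to compare.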

Compound 3, a percentage reported as activity, at one concentration (the size of the read-out at that concentration, not a potency): 49.7%
Beside the measured number, compound 3's estimate is 24.7 percentage points below it; measured number outside the range, above it.
By their numbers in this assay, from the lowest: compounds 2 and 1 (each within the scatter of the next); then compound 3.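

In this assay, going by these compounds alone, the inversion gives a number 22.6 percentage points higher from compound 1 to compound 3 (beyond the scatter), the first step in this set that can be read at all. That step can be put down to configuration alone, because no atom or bond changes: the fact that compounds 1 and 3 differ only in the configuration as drawn. The two saturated ring carbons drawn the other way round therefore matter to the effect seen at the one concentration tested, even with the same groups on the same shared core, something that compound 1 and compound 2, linked by no single change, could not show.

The two stereocentres differ together in this pair, so the compounds shown cannot tell whether one inversion alone would carry the step or whether both are needed, and a single-concentration read-out says nothing about potency. Also open, going by these compounds, is whether the configuration of compound 3 would keep its effect with a methoxy group in place of a hydroxyl group, or with an amine added to the shared core.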